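The source may report more compounds than this note shows. Statements on the series, on what has been measured and on what is new or still open speak of the compounds shown alone.

Measured so far:
Compound 1 `C=CCn1c(SCC(=O)c2ccccc2)nnc1-c1ccccc1` gives 43% in a functional assay on the whole organism (strain albino) for inhibition, with Rattus norvegicus as the target, read by paw edema, with a stated time of 1 h, at a dose of 0.28 mmol/kg by the oral route; on this read-out higher numbers stand for more inhibition at the one dose given (going by the name of the read-out) and lower numbers for less inhibition.
Compound 2 `C=CCn1c(SCC(=O)c2ccccc2)nnc1-c1ccc(OC)cc1` gives 49% in this assay.
Compound 3 `O=C(CSc1nnc(-c2ccccc2)n1-c1ccccc1)c1ccccc1` gives 53% in this assay.

Compound 4 `COc1ccc(-c2nnc(SCC(=O)c3ccccc3)n2-c2ccccc2)cc1` is not yet measured. It differs from compound 3 by methoxy in place of hydrogen on an aromatic carbon. The same change was made once already, from compound 1 to compound 2, where the difference is methoxy in place of hydrogen on an aromatic carbon; that step made a number 6 percentage points higher from compound 1 to compound 2 (within the scatter). The two cores on which the change sits are not the same: compound 3 differs from compound 1 by phenyl in place of allyl on an aromatic nitrogen, and that step made a number 10 percentage points higher from compound 1 to compound 3 (within the scatter). Since the step to compound 2 was small, the step from compound 3 to compound 4 is expected to be of similar size, a number 4 percentage points higher from compound 3 to compound 4 (within the scatter). On that basis compound 4 is estimated to give about 57%, most likely between 45% and 68%.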

Compound 4, a percentage reported as inhibition, in the whole organism at one dose (the size of the read-out at that dose, not a potency): 52%
The estimate for compound 4 lay 5 percentage points above the measured number; low and high end bracket the measured number.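

The methoxy change reads in this assay as a number 1 percentage points lower from compound 3 to compound 4 (within the scatter), and it agrees with its earlier step on the other core: the same change on two cores in this assay, a number 6 percentage points higher (within the scatter) from compound 1 to compound 2 and a number 1 percentage points lower (within the scatter) from compound 3 to compound 4, 7 percentage points apart, within the scatter of two such steps. The change from allyl to phenyl reads as a number 3 percentage points higher from compound 2 to compound 4 (within the scatter), and it agrees with its earlier step in the same way: the same change on two cores in this assay, a number 10 percentage points higher (within the scatter) from compound 1 to compound 3 and a number 3 percentage points higher (within the scatter) from compound 2 to compound 4, 7 percentage points apart, within the scatter of two such steps. Nothing here suggests that the core alters either change, but with every step inside the scatter, this does not show that either change has a real effect, nor that the agreement would hold on other cores.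

The compounds shown leave open what an amine or a carboxylic acid would do in place of methoxy. They also leave open what a longer chain would do in place of allyl on the aromatic nitrogen.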